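From pyridin-2-yl to cyclohexyl on a shared core

The source may report more compounds than this note shows. Statements on the series, on what has been measured and on what is new or still open speak of the compounds shown alone.

In a functional assay on the whole organism with Mus musculus as the target (on this read-out higher numbers stand for an effect only at larger amounts of compound and lower numbers for an effect already at smaller amounts), compound 1 `C[C@@H](NCc1ccc(OCc2ccccc2)cc1)C(N)=O` gives 23.8 mg/kg, while compound 2 `C[C@@H](NCc1ccc(OCc2ccccn2)cc1)C(N)=O` gives 172 mg/kg, the higher of the two numbers. For the measured compounds named here, the single measured step, a 7.2-fold higher number from compound 1 to compound 2 (0.86 log units; beyond the scatter), put pyridin-2-yl in place of phenyl and lies beyond the scatter. Compound 3 `C[C@@H](NCc1ccc(OCC2CCCCC2)cc1)C(N)=O` has not yet been measured. Its difference from compound 2 is this: cyclohexyl in place of pyridin-2-yl on a saturated chain carbon bound to an oxygen on an aromatic ring. Cyclohexyl thus stands in place of pyridin-2-yl on a saturated chain carbon bound to an oxygen on an aromatic ring. Going by the values given here, no measured step covers cyclohexyl itself. Compound 1 also carries a ring of carbon only, so much, but not all, of a 7.2-fold higher number from compound 1 to compound 2 (0.86 log units; beyond the scatter) is expected to be reversed in this assay. A lower number is therefore expected, an estimated 4.3-fold lower number from compound 2 to compound 3 (0.63 log units; beyond the scatter). For compound 3 the estimate is 40 mg/kg, with an expected range from 15 mg/kg to 120 mg/kg.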

Compound 3, dose for half-maximal effect: 131 mg/kg
Compound 3: the middle estimate sits 3.3-fold (0.52 log units) below what was measured; measured number above the stated range.
By their numbers in this assay, from the lowest: compound 1; then compounds 3 and 2 (each within the scatter of the next).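

In this assay, a 1.3-fold lower number from compound 2 to compound 3 (0.12 log units; within the scatter), so at this place, on a saturated chain carbon bound to an oxygen on an aromatic ring, cyclohexyl and pyridin-2-yl cannot be told apart. Against that, a 5.5-fold higher number from compound 1 to compound 3 (0.74 log units; beyond the scatter), which shows that a ring of carbon only is not enough to stay near compound 1: among the three compounds, phenyl alone gives the low number, and both replacements leave it by a step beyond the scatter. Nothing available here bears on why the numbers fall this way.

The compounds shown leave open whether any other group at this place can come close to phenyl, for instance a thienyl or a fluorophenyl ring. They also leave open whether an open butyl chain would fall with cyclohexyl and pyridin-2-yl.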